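Shortening the ester acyl group to methyl

A few compounds are considered here, and "the series" means these few. Any claim that something is new, unique, unknown or untested is made for them only; others in the source may bear on it.

The series shares a core bearing an ester and an amide, seen in compound 1 `O=C(OC1(C(=O)Nc2ccc([N+](=O)[O-])cc2)CCCCC1)c1ccc(C(F)(F)F)cc1`, compound 2 `Cc1ccc(C(=O)OC2(C(=O)Nc3ccc([N+](=O)[O-])cc3)CCCCC2)cc1` and compound 3 `O=C(/C=C/c1ccccc1)OC1(C(=O)Nc2ccc([N+](=O)[O-])cc2)CCCCC1`. In a functional assay on HepG2 cells (Homo sapiens) for inhibition, read by MTT assay, with a stated time of 72 h (on this read-out higher numbers stand for weaker inhibition and lower numbers for stronger inhibition), compound 1 gives 29.1 nM, compound 2 gives 61.2 nM and compound 3 gives 52.9 nM. Compound 3 thus stands second highest of the three numbers, close to compound 2 and a little apart from compound 1, though neither gap is beyond the scatter.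

Compound 4 `CC(=O)OC1(C(=O)Nc2ccc([N+](=O)[O-])cc2)CCCCC1` differs from compound 3 in one place: methyl in place of 2-phenylethenyl on a carbonyl carbon. For the measured compounds named here, the steps that bear on it are the earlier exchanges of the acyl group: a 1.8-fold higher number from compound 1 to compound 3 (0.26 log units; within the scatter) and a 1.2-fold lower number from compound 2 to compound 3 (0.06 log units; within the scatter). Going by the values given here, both were small, but both kept an aromatic ring, whereas compound 4 loses it entirely, and no measured compound shows what that does.

The account therefore expects a modest weakening, a 2.8-fold higher number from compound 3 to compound 4 (0.45 log units; beyond the scatter), in this assay. Compound 4 is estimated at 150 nM, within a range from 50 nM to 500 nM.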

Compound 4, half-maximal inhibitory concentration: 519 nM
Beside the measured number, compound 4's estimate is 3.5-fold (0.54 log units) below it; the measured number lies above the stated range.
By their numbers in this assay, from the lowest: compounds 1, 3 and 2 (each within the scatter of the next, the first and the last beyond it); then compound 4.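

In this assay the position on the carbonyl carbon proves far from indifferent to the group it carries: methyl gives a 9.8-fold higher number from compound 3 to compound 4 (0.99 log units; beyond the scatter) and an 8.5-fold higher number from compound 2 to compound 4 (0.93 log units; beyond the scatter) and also an 18-fold higher number from compound 1 to compound 4 (1.25 log units; beyond the scatter) in the same exchange. Each of these steps lies beyond the scatter and is larger than any step among compounds 1, 2 and 3, so among these four compounds the numbers stay low only while the acyl group keeps its aromatic ring. No measurement at hand accounts for this loss.

Methyl removes the ring, the double bond and most of the carbon atoms at once, so the compounds shown cannot tell these changes apart. On these data alone, how a longer chain such as butyl, a saturated 2-phenylethyl group or an unsubstituted phenyl would behave at this position remains open.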